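Exchanging the Chain Terminus of Compound 2

A few compounds are considered here, and "the series" means these few. Any claim that something is new, unique, unknown or untested is made for them only; others in the source may bear on it.

The measured compounds:
compound 1, `CN(C)c1cc2c(NC3CCCCC3)ncnc2cn1`, gives 199 nM in a functional assay on CHO cells for antagonist activity at metabotropic glutamate receptor 1 (Rattus norvegicus), with a stated time of 5 min; a lower number here means a stronger inhibitor, a higher number a weaker inhibitor.
compound 2, `COCCOc1cc2c(NC3CCCCC3)ncnc2cn1`, gives 101 nM in this assay .

Of the two numbers shown, compound 2 gives the lower one, with compound 1 as its only neighbour; the step of a 2.0-fold lower number from compound 1 to compound 2 (0.29 log units; within the scatter) lies within the scatter, so the two compounds cannot be ordered against each other. Compound 3, `O=C1CCCN1CCOc1cc2c(NC3CCCCC3)ncnc2cn1`, has not yet been measured. It differs from compound 2 in one place: 2-oxopyrrolidin-1-yl in place of methoxy on a saturated chain carbon, two bonds along the chain from an oxygen on an aromatic ring.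

Among the compounds with values here, only one measured step exists, a 2.0-fold lower number from compound 1 to compound 2 (0.29 log units; within the scatter), and it concerns the group attached directly to the aromatic carbon, not the far end of the chain. It bears on the present change only loosely, showing that a swap in this region of the molecule moved the number little. Within the data shown here, no measured step addresses the chain terminus itself. On that basis the step expected from compound 2 to compound 3 in this assay is a 1.5-fold higher number from compound 2 to compound 3 (0.17 log units; within the scatter), none beyond the scatter. Compound 3 is expected to give 150 nM, with a range from 50 nM to 500 nM.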

Compound 3, inhibition constant: 20 nM
Estimate against measurement, compound 3: 7.5-fold (0.88 log units) above, outside the stated range (below it).
By their numbers in this assay, from the lowest: compound 3; then compounds 2 and 1 (each within the scatter of the next).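

In this assay, within the data shown here, the far end of the chain proves to be a place where a change registers: 2-oxopyrrolidin-1-yl in place of methoxy gives a 5.1-fold lower number from compound 2 to compound 3 (0.70 log units; beyond the scatter), whereas the one earlier step, a 2.0-fold lower number from compound 1 to compound 2 (0.29 log units; within the scatter), did not separate its two compounds. The change adds heavy atoms and a five-membered non-aromatic ring with a double bond outside aromatic rings, while the counts of hydrogen-bond donors and acceptors are the same for the leaving and the entering group, and neither group carries a net charge. Nothing at hand bears on why the number moves as it does.

The compounds shown do not separate the contributions of the ring, the carbonyl and the added heavy atoms, and an open-chain acetamide or a plain pyrrolidine amine on the same saturated chain carbon would speak to that question. They also leave open whether the 2-(2-oxopyrrolidin-1-yl)ethyl group depends on its chain length, which a longer chain ending in the same 2-oxopyrrolidin-1-yl group would test.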